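A few compounds are considered here, and "the series" means these few. Any claim that something is new, unique, unknown or untested is made for them only; others in the source may bear on it.

Going by the values given here, compound 2 `COc1ccccc1-c1cn2ccnc2c(-c2ccc3ncn(C4CCCCC4)c3c2)n1` gives 22.6% in a functional assay on K562 cells (Homo sapiens) for inhibition, read by sulforhodamine B assay, with a stated time of 48 h, tested at 10 uM (on this read-out higher numbers stand for more inhibition at the one concentration tested (going by the name of the read-out) and lower numbers for less inhibition), the highest of the two numbers measured so far. Compound 1 `CC(=O)c1ccc(-c2cn3ccnc3c(-c3ccc4ncn(C5CCCCC5)c4c3)n2)cc1` gives 9.6% in this assay, and the step of a number 13 percentage points higher from compound 1 to compound 2 (beyond the scatter) changes only the group at the same position that now changes again. Compound 3 `c1csc(-c2cn3ccnc3c(-c3ccc4ncn(C5CCCCC5)c4c3)n2)c1` carries the change (thiophen-2-yl in place of 2-methoxyphenyl on an aromatic carbon). Among the compounds with values here, only that one step bears on it, and it was modest. A thiophen-2-yl is a new group here, so compound 3 is expected to show a number 6.6 percentage points lower from compound 2 to compound 3 (within the scatter), a small drop that may stay within the scatter. The estimate for compound 3 is 16%, with a range of 4% to 30%.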

Compound 3, a percentage reported as inhibition, at one concentration (the size of the read-out at that concentration, not a potency): 27%
Beside the measured number, compound 3's estimate is 11 percentage points below it, within the range that was stated.
By their numbers in this assay, from the lowest: compound 1; then compounds 2 and 3 (each within the scatter of the next).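

At this position the five-membered thiophen-2-yl, with fewer heavy atoms than the six-membered 2-methoxyphenyl, keeps the read-out in this assay level: the swap gives a number 4.4 percentage points higher from compound 2 to compound 3 (within the scatter) and so does not separate the two groups. Going by these compounds alone, replacing 4-acetylphenyl with thiophen-2-yl gives a number 17.4 percentage points higher from compound 1 to compound 3 (beyond the scatter) and leaves 4-acetylphenyl as the one group that sits apart at the low end. Nothing shown explains these differences. From the compounds shown here alone, whether a plain phenyl, a furan-2-yl or a group carrying an amine would read differently at this position stays open. Each value comes from a single concentration, so none of them describes potency.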